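Aryl urea series: isoquinoline in place of hydroxynaphthalene

The compounds below may be only part of what the source reports. "The series", "measured", "known", "first", "only" and "open" are said of these compounds alone.

Measured compounds:
compound 1, `CC(C(=O)NCc1ccc(C(F)(F)F)cc1N1CCC(Cc2ccccc2)(N(C)C)CC1)c1ccc(NS(C)(=O)=O)c(F)c1`, 8.2 nM
compound 2, `CN(C)C1(Cc2ccccc2)CCN(c2cc(C(F)(F)F)ccc2CNC(=O)NCc2ccc(NS(C)(=O)=O)c(F)c2)CC1`, 85.9 nM
compound 3, `CN(C)C1(Cc2ccccc2)CCN(c2cc(C(F)(F)F)ccc2CNC(=O)Nc2cccc3ccc(O)cc23)CC1`, 8.9 nM

In an assay on CHO cells for antagonist activity at transient receptor potential cation channel subfamily V member 1 (Homo sapiens), read by scintillation counting, with a stated time of 5 min, in the presence of a further agent that is not named here (a lower number here means that less compound is needed, a higher number that more compound is needed for the effect), compound 3 gives 8.9 nM. Against compound 1 the two numbers sit within the scatter of each other, so no order between them can be read. Against compound 2 the gap is beyond the scatter, and compound 3 takes the lower number of the pair.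

Compound 4, `CN(C)C1(Cc2ccccc2)CCN(c2cc(C(F)(F)F)ccc2CNC(=O)Nc2ccc3ccncc3c2)CC1`, has not yet been measured. It differs from compound 3 in one place: isoquinolin-7-yl in place of 7-hydroxynaphthalen-1-yl on an amide-type nitrogen. Both compounds keep the shared core and the urea link; the aryl group on the urea nitrogen changes from one bicyclic aromatic to another, and the hydroxyl donor is lost.

Within the data shown here, no step between two measured compounds covers this kind of change, so the expectation rests on the level of compound 3 alone. A modest move toward a higher number is expected, of a size a 1.7-fold higher number from compound 3 to compound 4 (0.23 log units; within the scatter), likely close to the scatter. Compound 4 is therefore estimated at 15 nM in this assay, within a range from 5 nM to 60 nM.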

Compound 4, half-maximal effective concentration: 56.1 nM
Compound 4: the middle estimate sits 3.7-fold (0.57 log units) below what was measured; the measured number falls inside the stated range.
By their numbers in this assay, from the lowest: compounds 1 and 3 (each within the scatter of the next); then compounds 4 and 2 (each within the scatter of the next).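

Among these compounds, at the aryl group on the urea nitrogen, isoquinolin-7-yl in place of 7-hydroxynaphthalen-1-yl gives in this assay a 6.3-fold higher number from compound 3 to compound 4 (0.80 log units; beyond the scatter) and provides the first single-place comparison. This position therefore does not treat these two bicyclic aromatic groups as interchangeable, even though both keep the shared core and the urea link. The change removes the hydroxyl and brings a ring nitrogen into the aromatic system in one step, so this pair cannot separate the two alterations.

Whether the hydroxyl alone accounts for the step remains open, and an amine or a methoxy group on the same naphthalene would bear on that question. No measurement at hand offers an explanation for the step.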